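A few compounds are considered here, and "the series" means these few. Any claim that something is new, unique, unknown or untested is made for them only; others in the source may bear on it.

Measured compounds:
- compound 1 `C=C1CCCC(C)(C)C1CC[C@]1(C)CC[C@H]([C@@H](C)C(=O)OC)OO1`: 3730 nM
- compound 2 `C=C1CCC[C@H]2[C@](C)(CC[C@]3(C)CC[C@@H]([C@@H](C)C(=O)O)OO3)[C@@H](C)CC[C@]12C`: 780 nM
- compound 3 `C=C1CCCC(C)(C)C1CC[C@@]1(C)CC[C@H]([C@@H](C)C(=O)O)OO1`: 11300 nM

All three have been measured in a functional assay on SN12C cells (Homo sapiens) for inhibition; a higher number here means a weaker inhibitor of growth, a lower number a stronger inhibitor of growth. Compound 2 gives the lowest number of the three; the nearest to it is compound 1, and the furthest is compound 3, and both of those gaps lie beyond the usual scatter. Compounds 1 and 3 differ from compound 2 in more than one place at once, so their values show only that they are weaker, not which feature accounts for it.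

Compound 4 `C=C1CCC[C@H]2[C@](C)(CC[C@]3(C)CC[C@H]([C@@H](C)C(=O)O)OO3)[C@@H](C)CC[C@]12C` has not yet been measured. Its relation to compound 2 is:

the two compounds have the same atoms and bonds and differ only in configuration as drawn: 1 of 7 stereo elements differ; a stereocentre at a saturated ring carbon is drawn S in compound 2 and R in compound 4

Within the data shown here, no pair of measured compounds differs by a single change of this kind, so there is no step to lean on. An inversion at a single ring carbon can leave the number where it is or move it either way; a modest loss is taken as the working assumption. Compound 4 is expected to give 1600 nM (range 500 nM to 5000 nM). The step of a 2.1-fold higher number from compound 2 to compound 4 (0.31 log units; beyond the scatter) is thus expected to be small and close to the edge of the scatter.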

Compound 4, concentration for 50% growth inhibition: 1780 nM
For compound 4 the middle estimate is 1.1-fold (0.05 log units) below the measured one; the range from low to high includes it.
By their numbers in this assay, from the lowest: compound 2; then compound 4; then compound 1; then compound 3.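

In this assay, among these compounds, inverting a saturated ring carbon from S to R gives a 2.3-fold higher number from compound 2 to compound 4 (0.36 log units; beyond the scatter), the first single change that can be read. The position therefore responds to configuration, though only modestly, and compound 4 still inhibits growth at 1780 nM. The step can be assigned to this one stereocentre alone, because nothing else separates the pair: the fact that compounds 2 and 4 differ only in the configuration as drawn

Among the compounds shown here, whether the same inversion gives a similar step on the core of compound 3 remains open, and no single-change pair here isolates the effect of the methyl ester against the carboxylic acid. From the compounds shown here alone, how a primary amide or a hydroxymethyl group in place of the carboxylic acid would behave with either configuration at this carbon also remains open.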